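Aminophenyl for methoxyphenyl on the pyridine-like core

The source may hold more compounds than are shown below. What is called first, only, known or untested is meant among the compounds shown, and "the series" means these compounds.

Measured compounds:
compound 1 `CCc1ccc(-c2cc(Cl)cc(C(=O)Nc3nn[nH]n3)n2)cc1` gives < 13% in a functional assay on the whole organism with Rattus norvegicus as the target, at a dose of 0.3 mg/kg by the oral route; on this read-out lower numbers stand for a weaker effect and higher numbers for a stronger effect at the one dose given
compound 2 `COc1cc(C(=O)Nc2nn[nH]n2)nc(-c2ccccc2OC)c1` gives 35% in this assay

Compound 1 sits at the limit of this assay, so its value is a limit and not a number (the limit of < 13% in this assay, at which 1 of the 2 values shown sits). For the measured compounds named here, compound 2 is therefore the only compound with a measured number, and it stands alone; no step between measured compounds is available to guide the next change.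

Compound 3 `COc1cc(C(=O)Nc2nn[nH]n2)nc(-c2ccc(N)cc2)c1` differs from compound 2 by one change: 4-aminophenyl in place of 2-methoxyphenyl on an aromatic carbon.

Going by the values given here, with no measured step to draw on, the size of this change can only be guessed. The account expects compound 3 to sit near compound 2, with a step of a number 5 percentage points lower from compound 2 to compound 3 (within the scatter) that stays within the scatter, though a fall toward the limit cannot be ruled out. Compound 3 is estimated at 30%, in the range from 10% to 55%.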

Compound 3, a percentage reported as inhibition, in the whole organism at one dose (the size of the read-out at that dose, not a potency): 12%
For compound 3 the middle estimate is 18 percentage points above the measured one; measured number inside the range.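

At this position, on an aromatic carbon next to the ring nitrogen, the aryl group matters at the one dose given: 4-aminophenyl in place of 2-methoxyphenyl produces a number 23 percentage points lower from compound 2 to compound 3 (beyond the scatter). For the compounds shown here, this is the first measured step, but it changes both the substituent and where it sits on the phenyl ring, so a single step cannot separate the two. The result also lies close to the bottom of the measurable range: the limit of < 13% in this assay, at which 1 of the 3 values shown sits.

On these data alone, it remains open whether the methoxy group or its location on the phenyl ring accounts for the difference, a question that 4-methoxyphenyl and 2-aminophenyl would help to separate. An unsubstituted phenyl group would show how either substituent compares with none.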